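Working notes: from compound 2 to compound 3

The source may hold more compounds than are shown below. What is called first, only, known or untested is meant among the compounds shown, and "the series" means these compounds.

Measured so far in an ADME assay on the whole organism for cytotoxicity, with Artemia salina as the target, with a stated time of 24 h (a lower number here means that less compound is needed, a higher number that more compound is needed for the effect), for the series
- compound 1 `COc1ccc(/C=C/C(=O)c2ccccc2NC(=O)NS(=O)(=O)c2ccc(C)cc2)cc1` gives 28.1 ug/mL
- compound 2 `CCc1cc(/C=C/C(=O)c2ccccc2NC(=O)NS(=O)(=O)c2ccc(C)cc2)cc(OC)c1OC` gives 19.2 ug/mL

Within the data shown here, compound 2 stands level with compound 1 on these numbers, and a 1.5-fold lower number from compound 1 to compound 2 (0.17 log units; within the scatter) is the only measured step. Compound 3 `Cc1ccc(S(=O)(=O)NC(=O)Nc2ccccc2C(=O)/C=C/c2cccc([N+](=O)[O-])c2)cc1` changes the same place on compound 2: 3-nitrophenyl in place of 3-ethyl-4,5-dimethoxyphenyl on a double-bonded chain carbon bound to a double-bonded chain carbon is the whole difference. Among the measured compounds shown here, the 3-nitrophenyl group has no measured precedent, so the one small step above is thin support. No shift beyond the scatter is expected in this assay here, and the expected step is a 1.1-fold higher number from compound 2 to compound 3 (0.06 log units; within the scatter) in size. For compound 3 the estimate is 22 ug/mL (expected range 8 ug/mL to 60 ug/mL).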

Compound 3, concentration for half-maximal effect: 44.5 ug/mL
Compound 3: the middle estimate sits 2.0-fold (0.31 log units) below what was measured, within the range that was stated.
By their numbers in this assay, from the lowest: compounds 2, 1 and 3 (each within the scatter of the next, the first and the last beyond it).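

In this assay the position on a double-bonded chain carbon bound to a double-bonded chain carbon now shows its first step beyond the scatter, with a 2.3-fold higher number from compound 2 to compound 3 (0.37 log units; beyond the scatter) when 3-nitrophenyl replaces 3-ethyl-4,5-dimethoxyphenyl. Against 4-methoxyphenyl the same group gives a 1.6-fold higher number from compound 1 to compound 3 (0.20 log units; within the scatter) and so separates from only one of the two earlier groups. No measurement here speaks to a cause for the step.

As far as these compounds go, compound 2 and compound 3 differ in all their ring substituents at once, so it stays open which of them carries the step. Also open, from the compounds shown here alone, is how an amine or a carboxylic acid on this phenyl ring would read in this assay at this position.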